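Cytotoxicity at the Limit: from Compound 2 to Compound 4

This account rests on a few compounds, and the source may have more. Where it says the series, first, only, none or still open, it means among the compounds named here.

Compound 1 `OB1OCc2ccc(-n3cc(Sc4cccc(Cl)c4)c4ccccc43)cc21`: in an ADME assay on L929 cells (Mus musculus) for cytotoxicity, read by resazurin assay, with a stated time of 72 h (a higher number here means a weaker inhibitor, a lower number a stronger inhibitor), compound 1 gives only a limit, > 10 ug/mL.
Compound 2 `CCCNC(=O)c1cccn1-c1ccc2c(c1)B(O)OC2`: in this assay compound 2 gives only a limit, > 10 ug/mL.
Compound 3 `O=C(c1ccccc1)c1ccn(-c2ccc3c(c2)B(O)OC3)c1`: in this assay compound 3 gives only a limit, > 10 ug/mL.

Among the compounds with values here, compound 2 stands where every measured compound stands, at the limit of > 10 ug/mL in this assay, at which 3 of the 3 values shown sit, so no number for it is known, and no step between measured compounds can be drawn from these results. Compound 4 `CC(=O)c1cccn1-c1ccc2c(c1)B(O)OC2` differs from compound 2 in one place: methyl in place of propylamino on a carbonyl carbon. Within the data shown here, with every measured value a limit, there is no measured step of this kind to lean on. The change is expected to give no step beyond the usual scatter, and the step that this estimate means, a number no higher from compound 2 to compound 4 (the limit leaves the size open), is expected to lie within that scatter. Compound 4 is therefore estimated at 10 ug/mL in this assay, between 5 ug/mL and 30 ug/mL, and it is expected most likely to be reported again only as a limit rather than as a number.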

Compound 4, half-maximal inhibitory concentration: > 10 ug/mL
Compound 4: only a limit was reported (the forecaster's own chance of this, stated with the estimate: 85%); the middle value sits exactly at the limit.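

Compound 2 and compound 4 are both reported in this assay only as limits, so no step can be read between them: the limit of > 10 ug/mL in this assay, at which 4 of the 4 values shown sit. The compounds shown leave open where any of them lies relative to that limit, and whether methyl in place of propylamino on a carbonyl carbon changes the read-out at all.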